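The source may report more compounds than this note shows. Statements on the series, on what has been measured and on what is new or still open speak of the compounds shown alone.

Working notes on the series. The shared core carries a variable group on an aromatic carbon of a six-membered aromatic ring with two nitrogens. Compound 1 `Brc1cn2ccnc2c(-c2ccc3ncn(C4CCCCC4)c3c2)n1` bears bromo there and in a functional assay on NCI/ADR-RES cells (Homo sapiens) for inhibition, read by sulforhodamine B assay, with a stated time of 48 h, tested at 10 uM (on this read-out lower numbers stand for less inhibition and higher numbers for more inhibition at the one concentration tested (going by the name of the read-out)), compound 1 gives 8.82%. Compound 2 `O=Cc1ccc(-c2cn3ccnc3c(-c3ccc4ncn(C5CCCCC5)c4c3)n2)cc1` bears 4-formylphenyl and compound 2 gives 37.4%. Compound 3 `c1ccc2c(-c3cn4ccnc4c(-c4ccc5ncn(C6CCCCC6)c5c4)n3)cccc2c1` bears naphthalen-1-yl and compound 3 gives 4.43%, the lowest of the three numbers; the step of a number 4.4 percentage points lower from compound 1 to compound 3 (within the scatter) lies within the scatter, while the step of a number 33 percentage points lower from compound 2 to compound 3 (beyond the scatter) is large.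

Compound 4 `COc1ccccc1-c1cn2ccnc2c(-c2ccc3ncn(C4CCCCC4)c3c2)n1` is the next member, not yet measured. Its change from compound 3 is 2-methoxyphenyl in place of naphthalen-1-yl on an aromatic carbon. Within the data shown here, the steps that bear on it are the two that lead into compound 3: an aryl group with one six-membered ring and an acceptor (compound 2) sat well above the naphthalen-1-yl compound, whereas bromo (compound 1) did not differ from it beyond the scatter. 2-Methoxyphenyl shares the single six-membered ring and one acceptor with 4-formylphenyl but the acceptor differs, so the direction is uncertain; a step up of modest size is expected, a number 11.6 percentage points higher from compound 3 to compound 4 (beyond the scatter), though it may stay within the scatter. Compound 4 is estimated at 16%, with a range from 0% to 40%.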

Compound 4, a percentage reported as inhibition, at one concentration (the size of the read-out at that concentration, not a potency): 0.06%
Compound 4: middle estimate off by 15.9 percentage points, on the high side, and the stated range covers the measured number.
By their numbers in this assay, from the lowest: compounds 4, 3 and 1 (each within the scatter of the next); then compound 2.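

Against compound 2, the change to 2-methoxyphenyl gives a number 37.3 percentage points lower from compound 2 to compound 4 (beyond the scatter) in this assay; an aryl group with a single six-membered aromatic ring of carbon only and a hydrogen-bond acceptor is therefore not enough at this position to reach the number of compound 2. The other two steps, a number 4.4 percentage points lower from compound 3 to compound 4 (within the scatter) and a number 8.8 percentage points lower from compound 1 to compound 4 (within the scatter), show that bromo, naphthalen-1-yl and 2-methoxyphenyl cannot be told apart here, so among the four compounds only the 4-formylphenyl compound stands beyond the scatter of the rest. No supporting data bear on the gap between compound 2 and compound 4, and its origin remains unassigned.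

Going by these compounds, it remains open whether the higher number of compound 2 follows the formyl group itself or where that group sits on the phenyl ring, a question that 4-methoxyphenyl and 2-formylphenyl groups would help to separate. On these data alone, it is equally open whether a carboxylic acid or an amine on the same phenyl ring would stand with compound 2 or with the other three compounds.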